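A few compounds are considered here, and "the series" means these few. Any claim that something is new, unique, unknown or untested is made for them only; others in the source may bear on it.

Measured so far:
compound 1 `O=C(O)[C@H]1[C@@H]2C[C@H](OC3CCN(c4ccc(-c5nc6cc(C(F)(F)F)ccc6[nH]5)cn4)CC3)C[C@@H]21` — 4.3 nM
compound 2 `O=C(O)[C@H]1[C@@H]2C[C@@H](OC3CCN(c4ccc(-c5nc6cc(C(F)(F)F)ccc6[nH]5)cn4)CC3)C[C@@H]21` — 22 nM

In an assay on isolated protein for inhibition of diacylglycerol O-acyltransferase 1 (Mus musculus) (on this read-out higher numbers stand for weaker inhibition and lower numbers for stronger inhibition), compound 2 gives the higher of the two numbers; compound 1 gives the lower, and the step of a 5.1-fold higher number from compound 1 to compound 2 (0.71 log units; beyond the scatter) rests on the single difference in configuration (the fact that compounds 1 and 2 differ only in the configuration as drawn). Compound 3 `O=C(O)[C@@H]1[C@@H]2C[C@H](OC3CCN(c4ccc(-c5nc6cc(C(F)(F)F)ccc6[nH]5)cn4)CC3)C[C@@H]21` is next: the two compounds have the same atoms and bonds and differ only in configuration as drawn: 2 of 4 stereo elements differ; a stereocentre at a saturated ring carbon is drawn r in compound 2 and s in compound 3; a stereocentre at a saturated ring carbon is drawn s in compound 2 and r in compound 3. Within the data shown here, the only measured step concerns one of the two centres that change here, and it was modest; the other centre, carrying the carboxylic acid, has no measured counterpart, so the step of a 1.5-fold lower number from compound 2 to compound 3 (0.17 log units; within the scatter) in this assay is expected only with wide uncertainty. Compound 3 is estimated at 15 nM, in a range from 3 nM to 80 nM.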

Compound 3, half-maximal inhibitory concentration in the diacylglycerol O-acyltransferase 1 assay: 74 nM
The estimate for compound 3 lay 4.9-fold (0.69 log units) below the measured number; measured number inside the range.
By their numbers in the diacylglycerol O-acyltransferase 1 assay, from the lowest: compound 1; then compound 2; then compound 3.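

In the diacylglycerol O-acyltransferase 1 assay the stereocentre carrying the carboxylic acid now has a single-centre step of its own, which is large: a 17-fold higher number from compound 1 to compound 3 (1.24 log units; beyond the scatter). In the diacylglycerol O-acyltransferase 1 assay the other stereocentre gave a modest step: a 5.1-fold higher number from compound 1 to compound 2 (0.71 log units; beyond the scatter). With both centres changed, in the diacylglycerol O-acyltransferase 1 assay the step is a 3.4-fold higher number from compound 2 to compound 3 (0.53 log units; beyond the scatter). In a physicochemical assay for lipophilicity, read by HPLC (a lower number here means a more polar compound, a higher number a more lipophilic compound), compound 2 gives 1.87 and compound 3 gives 1.88, and the same pair shows a number 0.01 log units higher from compound 2 to compound 3 (within the scatter). The large step rests on configuration alone: the fact that compounds 1 and 3 differ only in the configuration as drawn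

From the compounds shown here alone, whether this order holds with a primary amide or a tetrazole in place of the carboxylic acid remains open. Going by these compounds, the number for the isomer with both centres changed from compound 1 also remains open.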